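The source may hold more compounds than are shown below. What is called first, only, known or untested is meant among the compounds shown, and "the series" means these compounds.

For the measured compounds named here, compound 2 `COc1cc(OC)cc(N2CCN(c3nc(=O)c4cc(C(F)(F)F)cc([N+](=O)[O-])c4s3)CC2)c1` is one of two compounds so far read in a toxicity assay on HeLa cells (Homo sapiens) for cytotoxicity, read by colorimetric assay, with a stated time of 72 h; on this read-out higher numbers stand for lower toxicity in this test and lower numbers for higher toxicity in this test. In this assay compound 2 gives > 101000 nM, a value that is a limit of the assay and not a number. Its partner, compound 1 `N#Cc1cccc(N2CCN(c3nc(=O)c4cc(C(F)(F)F)cc([N+](=O)[O-])c4s3)CC2)c1`, carries a 3-cyanophenyl on the amine nitrogen in the ring where compound 2 carries a 3,5-dimethoxyphenyl. In this assay compound 1 gives > 108000 nM, again a limit of the assay. The step that the two limits leave unreadable from compound 1 to compound 2 therefore cannot be sized, since both the limit of > 108000 nM in this assay, at which 1 of the 2 values shown sits, and the limit of > 101000 nM in this assay, at which 1 of the 2 values shown sits, mark only where the readable range ends. Compound 3 `O=C(CN1CCN(c2nc(=O)c3cc(C(F)(F)F)cc([N+](=O)[O-])c3s2)CC1)Nc1ccccc1` differs from compound 2 by (phenylcarbamoyl)methyl in place of 3,5-dimethoxyphenyl on an amine nitrogen in a ring. Going by the values given here, the one measured step bears on this change only in that an exchange of the group on that ring nitrogen left both compounds at a limit. Nothing measured points to a step beyond the scatter in either direction, so compound 3 is expected to stay at or near the limit, with an estimated step of a number no higher from compound 2 to compound 3 (the limit leaves the size open). The estimate for compound 3 is 100000 nM, between 30000 nM and 300000 nM.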

Compound 3, half-maximal cytotoxic concentration: > 101000 nM
Compound 3 gave a limit, no number; the forecaster's own chance of this, stated with the estimate: 75%; middle value at least 1.0-fold (0.00 log units) from the limit.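

For the compounds shown here, no step among compound 1, compound 2 and compound 3 can be read; all three values are limits of the assay and not numbers. The compounds shown leave open whether exchanging the group on the amine nitrogen in the ring changes the half-maximal cytotoxic concentration at all, and how large any such change would be.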